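Dropping the chloro from the hydrazone arm of compound 2

The source may report more compounds than this note shows. Statements on the series, on what has been measured and on what is new or still open speak of the compounds shown alone.

Compound 1 `COc1ccc(OC)c(/C=C/c2nnc(Nc3ccc(Cl)cc3)o2)c1`: 7850 nM
Compound 2 `COc1ccc(OC)c(/C=C/C(=O)N/N=C/c2ccc(Cl)cc2)c1`: 13900 nM

In a functional assay on SK-OV-3 cells (Homo sapiens) for antiproliferative activity, read by sulforhodamine B assay, with a stated time of 48 h (a lower number here means a stronger inhibitor of growth, a higher number a weaker inhibitor of growth), compound 2 gives 13900 nM, the highest of the two numbers measured; compound 1 gives 7850 nM, a difference that lies within the scatter, so no order between them is claimed. Compound 3 `COc1ccc(OC)c(/C=C/C(=O)N/N=C/c2ccccc2)c1` differs from compound 2 by hydrogen in place of chloro on an aromatic carbon. Among the compounds with values here, no measured pair shows this change, so only a modest step is expected, if any, with the number expected to drift slightly higher rather than lower and not beyond the scatter. The step expected here is a 1.3-fold higher number from compound 2 to compound 3 (0.11 log units; within the scatter). Compound 3 is therefore estimated at 18000 nM, within 7000 nM to 45000 nM.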

Compound 3, concentration for total growth inhibition: > 100000 nM
Compound 3 was reported as a limit; the forecaster's own chance of this, stated with the estimate: 10%; at least 5.5-fold (0.74 log units) between middle value and limit.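

In this assay, the change from 4-chlorophenyl to phenyl, on an aromatic carbon para to a large group, gives an at least 7.1-fold higher number from compound 2 to compound 3 (0.85 log units; beyond the scatter). Compound 3 gives > 100000 nM, which is a limit of the assay and not a number. The chloro at this position therefore matters to the growth inhibition seen with compound 2, and the step has a lower bound only: the limit of > 100000 nM in this assay, at which 1 of the 3 values shown sits.

Going by these compounds, what a methoxy or an amine would do at this position stays open. So does whether the chloro matters in the same way on the core of compound 1.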